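Compound 2 to compound 3: hydroxy to acetoxy

This account rests on a few compounds, and the source may have more. Where it says the series, first, only, none or still open, it means among the compounds named here.

Three compounds on a shared core are followed here in a functional assay on HeLa cells (Homo sapiens) for cytotoxicity, read by MTT assay; a lower number here means a stronger inhibitor, a higher number a weaker inhibitor. Compound 1 is `C/C=C(\C)C(=O)O[C@@H]1[C@@H]2OC[C@]3(C)[C@H](OC(C)=O)C[C@H](OC(C)=O)[C@@](C)([C@@H]23)[C@H]2C[C@H](OC)O[C@H]3C[C@@H](C4=CCOC4=O)C(C)=C3[C@]12C`, and compound 2 is `C/C=C(\C)C(=O)O[C@@H]1[C@@H]2OC[C@]3(C)[C@H](OC(C)=O)C[C@H](O)[C@@](C)([C@@H]23)[C@H]2CCO[C@H]3C[C@@H](C4=CCOC4=O)C(C)=C3[C@]12C`. In this assay compound 1 gives > 100000 nM, which is a limit of the assay and not a number. In this assay compound 2 gives > 100000 nM, which is likewise a limit. Compound 2 therefore has no numerical value and stands with compound 1 at the limit of > 100000 nM in this assay, at which 2 of the 2 values shown sit. Among the measured compounds shown here, no step between measured compounds is available.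

Compound 3 is `C/C=C(\C)C(=O)O[C@@H]1[C@@H]2OC[C@]3(C)[C@H](OC(C)=O)C[C@H](OC(C)=O)[C@@](C)([C@@H]23)[C@H]2CCO[C@H]3C[C@@H](C4=CCOC4=O)C(C)=C3[C@]12C`. It differs from compound 2 by one change, acetyl in place of hydrogen on an oxygen on a saturated carbon, or hydroxy to acetoxy.

The only reference point for this change is compound 2, whose reading of > 100000 nM is a limit. No shift beyond the scatter is expected in this assay, and the reading is expected to stay at or near that limit. The expected step is a number no higher from compound 2 to compound 3 (the limit leaves the size open). The estimate for compound 3 is 100000 nM, with an expected range of 50000 nM to 200000 nM.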

Compound 3, half-maximal inhibitory concentration: > 100000 nM
Compound 3 ended at the assay's limit (the forecaster's own chance of this, stated with the estimate: 85%); the middle value lies on the limit itself.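

No new step can be read: compound 1, compound 2 and compound 3 all give limits in this assay, which leave the steps among them unreadable: the limit of > 100000 nM in this assay, at which 3 of the 3 values shown sit.

The compounds shown leave open whether acetyl in place of hydrogen, or hydrogen in place of methoxy, changes the reading at all, and what on the shared core would bring a measurable value.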